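The source may hold more compounds than are shown below. What is called first, only, known or untested is meant among the compounds shown, and "the series" means these compounds.

Working notes on the series. Compound 1 `CCCCc1cnc(Cc2ccc(-c3ccccc3C(=O)O)cc2)[nH]1` and compound 2 `O=C(O)c1ccccc1-c1ccc(CCc2ncc(CCc3ccccc3)[nH]2)cc1` share the core, with compound 3 `O=C(O)c1ccccc1-c1ccc(CCc2ncc(Cc3ccccc3)[nH]2)cc1` still to be tested. In an in vitro functional assay on cells for agonist activity at Bombesin receptor subtype-3 (Mus musculus), read by luminescence and calcium flux (on this read-out lower numbers stand for an effect already at smaller amounts and higher numbers for an effect only at larger amounts of compound), compound 2 gives 174 nM. For compound 1 this assay reports only a limit, > 10000 nM. Within the data shown here, compound 2 thus stands as the sole number in the set, the other result being a limit (the limit of > 10000 nM in this assay, at which 1 of the 2 values shown sits).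

Compound 3 differs from compound 2 by phenyl in place of benzyl on a saturated chain carbon bound to an aromatic carbon. Among the measured compounds shown here, no step between two measured compounds is available to size this change, so any expectation rests on compound 2 alone. In this assay the expected step is a 2.3-fold higher number from compound 2 to compound 3 (0.36 log units; beyond the scatter), a modest move toward larger amounts that may not clear the usual scatter. Compound 3 is estimated at 400 nM, with a range from 100 nM to 2000 nM.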

Compound 3, half-maximal effective concentration: 11 nM
Beside the measured number, compound 3's estimate is 36-fold (1.56 log units) above it, outside the stated range (below it).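

Phenyl in place of benzyl on a saturated chain carbon bound to an aromatic carbon gives a 16-fold lower number from compound 2 to compound 3 (1.20 log units; beyond the scatter) in this assay, the first measured size for any change at this place. The read-out at this place therefore responds strongly to a difference of a single chain carbon, seen as phenethyl to benzyl, although this rests on one pair and sets no trend. Nothing in the values shown gives a reason for the size of this step.

Still open, on these data alone, is how the read-out would respond to a longer chain such as phenylpropyl, or to a chain ending in a cyclohexyl ring in place of the aromatic ring. Also open, as far as these compounds go, is whether an amine or a methoxy group on the terminal phenyl would keep the number of compound 3 at 11 nM.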